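The source may report more compounds than this note shows. Statements on the series, on what has been measured and on what is new or still open speak of the compounds shown alone.

In a functional assay on MGC-803 cells (Homo sapiens) for antiproliferative activity, read by CCK-8 assay, with a stated time of 72 h (on this read-out lower numbers stand for stronger inhibition and higher numbers for weaker inhibition), the compounds measured so far read as follows:

compound 1 `C/C(=N\O)c1ccc(OCc2ccc(C(=O)NO)cc2)cc1` gives "not determined" (no result reported)
compound 2 `Nc1ccccc1NC(=O)c1ccc(COc2ccc([N+](=O)[O-])cc2)cc1` gives > 32000 nM
compound 3 `O=C(NO)c1ccc(COc2ccccc2)cc1` gives "not determined" (no result reported)

Only compound 2 has a reading, and even that is not a number. Compound 2 stands at > 32000 nM in this assay (a limit of the assay). That reading is the limit of > 32000 nM in this assay, at which 1 of the 3 values shown sits, and so it marks a boundary and not a point on the scale. Compound 1 and compound 3 have no result to compare with it, so no measured step exists between any of these compounds.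

The next compound is compound 4 `COc1ccc(OCc2ccc(C(=O)Nc3ccccc3N)cc2)cc1` which keeps the rest of compound 2 and carries methoxy in place of nitro on an aromatic carbon, para to a large group methoxy in place of nitro on an aromatic carbon (4-nitrophenyl to 4-methoxyphenyl).

Within the data shown here, no measured pair shows what this swap does in this assay so any expectation here is loose. Among the measured compounds shown here, the only anchor is compound 2 with its limit of > 32000 nM and from it a modest move towards stronger inhibition is expected, or none beyond the scatter. The estimated step of an at least 1.6-fold lower number from compound 2 to compound 4 (0.20 log units; that floor lies within the scatter) is therefore small, and the result may again be only a limit. For compound 4 the expected value is 20000 nM with an estimated range from 6000 nM to 60000 nM (an estimate only).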

Compound 4, half-maximal inhibitory concentration: 3480 nM
Beside the measured number, compound 4's estimate is 5.7-fold (0.76 log units) above it; the measured number lies below the stated range.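

In this assay, methoxy in place of nitro on an aromatic carbon, para to a large group, brings an at least 9.1-fold lower number from compound 2 to compound 4 (0.96 log units; beyond the scatter). Among these compounds, this shows that the group at this position can move the reading beyond the usual scatter, which the earlier compounds could not show. Compound 4 also supplies a real number on the scale, something that none of the earlier entries offered. The true size of the step remains unknown because compound 2 is held only by a limit of the assay: the limit of > 32000 nM in this assay, at which 1 of the 4 values shown sits.

This single pair cannot separate what leaving nitro contributes from what methoxy contributes, and it says nothing about why the reading moves. An amine or a longer chain such as ethoxy at the same position would help show whether the result is specific to methoxy or whether other replacements for nitro give a similar reading.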